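The source may hold more compounds than are shown below. What is called first, only, known or untested is meant among the compounds shown, and "the series" means these compounds.

Compound 2 `COc1ccc(-c2cc(=O)c3c(OC)cc(OC)cc3n2S(=O)(=O)c2ccc(Cl)cc2)cc1` carries a 4-chlorophenyl on the sulfonyl sulfur. In an ADME assay on BJ cells (Homo sapiens) for antiproliferative activity, with a stated time of 72 h (on this read-out higher numbers stand for an effect only at larger amounts of compound and lower numbers for an effect already at smaller amounts), compound 2 gives > 34400 nM, which is a limit of the assay rather than a number. Compound 1 `COc1ccc(-c2cc(=O)c3c(OC)cc(OC)cc3n2S(=O)(=O)c2c(F)c(F)c(F)c(F)c2F)cc1` differs from it only by 2,3,4,5,6-pentafluorophenyl in that place. In this assay compound 1 likewise gives > 34400 nM, again a limit. Among the measured compounds shown here, the step that the two limits leave unreadable from compound 1 to compound 2 therefore cannot be read, and the series offers no readable step at all, the only evidence being (the limit of > 34400 nM in this assay, at which 2 of the 2 values shown sit). Compound 3 `COc1ccc(-c2cc(=O)c3c(OC)cc(OC)cc3n2S(=O)(=O)c2cc(Cl)cc(Cl)c2O)cc1` is the next member, differing from compound 2 by 3,5-dichloro-2-hydroxyphenyl in place of 4-chlorophenyl on a sulfonyl sulfur. For the measured compounds named here, no measured step bears on the added hydroxyl or the second chlorine on this ring. The expected step that the limit leaves unreadable from compound 2 to compound 3 rests on the two limits alone and is estimated as none beyond the scatter. Compound 3 is therefore expected to give about 40000 nM in this assay, with a range from 10000 nM to 160000 nM, most probably again reported only as a limit.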

Compound 3, half-maximal effective concentration: > 37900 nM
Compound 3 was reported as a limit; the forecaster's own chance of this, stated with the estimate: 70%; the middle value is on the limit's open side.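

In this assay compound 3 gives > 37900 nM, a limit of the assay. Among the compounds shown here, with compound 1, compound 2 and compound 3 all reported as limits, no step among them can be read. On these data alone, whether any of these three groups on the sulfonyl sulfur differs from the others in this assay stays open.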